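A few compounds are considered here, and "the series" means these few. Any claim that something is new, unique, unknown or untested is made for them only; others in the source may bear on it.

Of the compounds shown here, three sharing one core have been measured in an assay on HeLa cells for inhibition of Kinesin-like protein KIF15 (Homo sapiens), read by microscopy, with stated times of 2 s and 20 s, tested at 750 nM; on this read-out lower numbers stand for less inhibition and higher numbers for more inhibition at the one concentration tested (going by the name of the read-out). Compound 1 `O=C1Nc2ccc(C(=O)c3ccco3)cc2/C1=C/c1ccc(O)c(C(F)(F)F)c1` gives 9.5%, compound 2 `COc1ccc(/C=C2\C(=O)Nc3ccc(C(=O)c4ccco4)cc32)cc1Br` gives 2.3%, and compound 3 `CN(C)C(=O)c1ccc2c(c1)/C(=C/c1cc(Cl)c(O)c(Cl)c1)C(=O)N2` gives 15.3%. Compound 3 stands highest of the three numbers; its nearest neighbour is compound 1, whose number lies lower by an amount within the usual scatter, while compound 2 lies furthest, lower by an amount beyond the scatter. Compound 4 `O=C1Nc2ccc(I)cc2/C1=C/c1cc(Cl)c(O)c(Cl)c1` has not yet been measured. It differs from compound 3 in one place: iodo in place of dimethylcarbamoyl on an aromatic carbon. Within the data shown here, no pair of measured compounds differs in exactly one place, so no measured step shows how much such a change moves the number. Because compound 3 gives 15.3% and the other two measured numbers are also modest, the step of a number 1.3 percentage points lower from compound 3 to compound 4 (within the scatter) in this assay is expected to be small, within the scatter, in no clear direction. Compound 4 is therefore estimated at 14%, with a range from 3% to 32%.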

Compound 4, a percentage reported as inhibition, at one concentration (the size of the read-out at that concentration, not a potency): 15%
Beside the measured number, compound 4's estimate is 1 percentage points below it; the range from low to high includes it.
By their numbers in this assay, from the lowest: compounds 2, 1, 4 and 3 (each within the scatter of the next, the first and the last beyond it).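

In this assay, among these compounds, the first single change that can be read is a number 0.3 percentage points lower from compound 3 to compound 4 (within the scatter). At this aromatic carbon of the shared core, dimethylcarbamoyl, with five heavy atoms and a hydrogen-bond acceptor, gives way to iodo, a single heavy atom with no acceptor, and the number does not move beyond the scatter, so neither group is set apart from the other in this read-out at the one concentration tested. No measurement is available that would explain this result.

As far as these compounds go, whether an amine, a carboxylic acid or a longer chain at this carbon would shift the number remains open. From the compounds shown here alone, it is also open whether the same exchange would leave the number in place with other groups elsewhere on the shared core, or at other concentrations.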